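The source may report more compounds than this note shows. Statements on the series, on what has been measured and on what is new or still open speak of the compounds shown alone.

Of the compounds shown here, three built on one shared core have been tested in a functional assay on MCF7 cells (Homo sapiens) for antiproliferative activity, read by MTT assay, with a stated time of 72 h; on this read-out lower numbers stand for stronger inhibition and higher numbers for weaker inhibition. Compound 2 `O=C(Nc1ccc(Cl)c(-c2nnc3c(Cl)cccn23)c1)c1cccc(Cl)c1` gives 71900 nM. Compound 1 `O=C(Nc1ccc(Cl)c(-c2nnc3c(Cl)cccn23)c1)c1ccc(C(F)(F)F)cc1Cl`, which differs from it on the ring joined to the carbonyl, gives 81600 nM, a number within the usual scatter of that of compound 2. Compound 3 `O=C(Nc1ccc(Cl)c(-c2nnc3c(Cl)cccn23)c1)c1c(F)cccc1Cl` gives > 100000 nM, which is a limit of this assay and not a number, namely (the limit of > 100000 nM in this assay, at which 1 of the 3 values shown sits). Compound 4 `O=C(Nc1ccc(Cl)c(-c2nnc3c(Cl)cccn23)c1)c1ccccc1` has not yet been measured. It differs from compound 2 in one place: hydrogen in place of chloro on an aromatic carbon. For the measured compounds named here, the only measured step on that ring, an at least 1.3-fold higher number from compound 2 to compound 3 (0.14 log units; that floor lies within the scatter), exchanges one substituted ring for another, and its floor lies within the scatter. Going by the values given here, no measured step removes the chloro outright, so the expectation rests on the uniformly weak numbers of the three measured compounds. Compound 4 is therefore expected to show a step of a 1.4-fold higher number from compound 2 to compound 4 (0.14 log units; within the scatter), leaning toward a higher number and thus weaker inhibition. The estimate for compound 4 in this assay is 100000 nM, with a range from 50000 nM to 200000 nM.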

Compound 4, half-maximal inhibitory concentration: > 100000 nM
Compound 4: a limit, no number; the forecaster's own chance of this, stated with the estimate: 40%; the middle value sits exactly at the limit.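

Taking the chloro away and leaving only hydrogen on that ring is a change in a single place, and in this assay it reads an at least 1.3-fold higher number from compound 2 to compound 4 (0.14 log units; that floor lies within the scatter). On these data alone, the result for compound 4 is a limit and not a number, so the size of this change stays unknown beyond that floor, but the bare benzoyl group shows no gain in inhibition. The step between compound 3 and compound 4 cannot be read, and the series now reaches the top of the assay's range more often: the limit of > 100000 nM in this assay, at which 2 of the 4 values shown sit.

As far as these compounds go, whether any group on this aromatic carbon can bring the numbers well down remains open. An amine, a methoxy group or a carboxylic acid in place of the chloro would each put a different kind of group there.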